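This account rests on a few compounds, and the source may have more. Where it says the series, first, only, none or still open, it means among the compounds named here.

For the measured compounds named here, compound 1, `N#Cc1cccc(C(=O)NC2CCCC(NC(=O)c3ccccn3)C2)c1`, is the only compound here that comes with a measured number: in a functional assay on HEK293 cells for antagonist activity at metabotropic glutamate receptor 5 (Homo sapiens), read by FLIPR and calcium flux (on this read-out higher numbers stand for weaker inhibition and lower numbers for stronger inhibition), compound 1 gives 531 nM. Compound 2, `N#Cc1cccc(C(=O)N[C@@H]2CCC[C@H](NC(=O)c3ccccn3)C2)c1`, has the same atoms and bonds, but both stereocentres on the saturated ring are drawn with a defined configuration. For compound 2 this assay reports only a limit, > 10000 nM. Going by the values given here, the change an at least 18-fold higher number from compound 1 to compound 2 (1.27 log units; beyond the scatter) goes back to the fact that one of compounds 1 and 2 is drawn with a defined configuration and the other without, at the place where they differ, so the single measured step concerns stereochemistry alone. Compound 3, `O=C(NC1CCCC(NC(=O)c2ccccn2)C1)c1cccc(Cl)c1`, differs from compound 1 in a different way: chloro in place of cyano on an aromatic carbon. Among the compounds with values here, no measured step touches a change of this kind, so nothing here points to a direction for it. The estimate for compound 3 therefore stays close to compound 1, and the step of a 1.1-fold higher number from compound 1 to compound 3 (0.05 log units; within the scatter) is expected to lie within the scatter. The expected value for compound 3 in this assay is 600 nM, in a range from 200 nM to 2000 nM.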

Compound 3, half-maximal inhibitory concentration: 314 nM
Estimate against measurement, compound 3: 1.9-fold (0.28 log units) above; the range from low to high includes it.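

For the compounds shown here, the earlier compounds gave a step only in stereochemistry; this is the first step at the aromatic ring. In this assay there is a 1.7-fold lower number from compound 1 to compound 3 (0.23 log units; within the scatter), so at this place, on an aromatic carbon and meta to a large group, the nitrile can give way to chloro without the result leaving the scatter, and the two groups cannot be told apart here. Nothing measured here gives a cause for this result.

Going by these compounds, it remains open how a quite different group at this place, such as an amine or a carboxylic acid, would behave. On these data alone, compound 3 is also drawn without a defined configuration at its saturated ring carbons, so how its stereo forms compare remains unknown.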